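The source may report more compounds than this note shows. Statements on the series, on what has been measured and on what is new or still open speak of the compounds shown alone.

Measured so far in an assay on a protein complex for inhibition of CDK8/Cyclin C (Homo sapiens), with a stated time of 1 h; a lower number here means a stronger inhibitor, a higher number a weaker inhibitor: compound 1 `O=C(O)/C=C/c1ccncc1-c1ccc2ccccc2c1` gives 5 nM; compound 2 `CN(C)C(=O)/C=C/c1ccncc1-c1ccc2ccccc2c1` gives 30.1 nM.

Compound 2 stands highest of the two numbers in this assay; its nearest neighbour is compound 1, and the step of a 6.0-fold higher number from compound 1 to compound 2 (0.78 log units; beyond the scatter) lies beyond the scatter.

Compound 3 `O=C(O)CCc1ccncc1-c1ccc2ccccc2c1` is not yet measured. Its change from compound 2 is 2-carboxyethyl in place of 2-(dimethylcarbamoyl)ethenyl on an aromatic carbon. This is not one of the measured steps: the acid of compound 1 returns, but the ethenyl linker is saturated at the same time. Going by the values given here, the only step that bears on it is the one a 6.0-fold higher number from compound 1 to compound 2 (0.78 log units; beyond the scatter), which concerns the acid-to-amide exchange alone; nothing measured speaks to the saturated chain. The expected direction in this assay is therefore toward compound 1, with the size of that step as an upper bound and wide uncertainty.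

For compound 3 the estimate in this assay is 10 nM, range 3 nM to 40 nM, corresponding to an expected step of a 3.0-fold lower number from compound 2 to compound 3 (0.48 log units; beyond the scatter).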

Compound 3, half-maximal inhibitory concentration: 50.5 nM
Beside the measured number, compound 3's estimate is 5.1-fold (0.70 log units) below it; the whole stated range lies below it.
By their numbers in this assay, from the lowest: compound 1; then compounds 2 and 3 (each within the scatter of the next).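

In this assay, going by these compounds alone, the step of a 10-fold higher number from compound 1 to compound 3 (1.00 log units; beyond the scatter) gives the first reading on the chain itself: with the carboxylic acid kept, 2-carboxyethyl in place of 2-carboxyethenyl shows that the acid alone does not account for the low number of compound 1, and that the ethenyl linker counts as well. The step of a 1.7-fold higher number from compound 2 to compound 3 (0.22 log units; within the scatter) lies within the scatter, so the dimethylamide on the ethenyl chain and the acid on the saturated chain cannot be told apart in this assay. Nothing at hand explains why the saturated chain reads as it does.

Open, as far as these compounds go, is how a primary amide or a tetrazole would read on the ethenyl chain, and how a dimethylamide would read on the saturated chain. From the compounds shown here alone, a longer chain ending in a carboxylic acid also remains open.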